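Cyclopentylmethoxy in place of butoxy on the shared core

A few compounds are considered here, and "the series" means these few. Any claim that something is new, unique, unknown or untested is made for them only; others in the source may bear on it.

compound 1 `O=C(NCc1ccc(C(F)(F)F)nc1N1CCCCC1)Nc1cccc2c(=O)[nH]ccc12`: 13.2 nM
compound 2 `CCCN(CCC)c1nc(C(F)(F)F)ccc1CNC(=O)Nc1cccc2c(=O)[nH]ccc12`: 2.79 nM
compound 3 `CCCCOc1nc(C(F)(F)F)ccc1CNC(=O)Nc1cccc2c(=O)[nH]ccc12`: 160 nM

All three were tested in an assay on CHO cells for agonist activity at transient receptor potential cation channel subfamily V member 1 (Homo sapiens); on this read-out lower numbers stand for an effect already at smaller amounts and higher numbers for an effect only at larger amounts of compound. Compound 3 gives the highest number of the three, and both steps leading to it are large: a 12-fold higher number from compound 1 to compound 3 (1.08 log units; beyond the scatter) and a 57-fold higher number from compound 2 to compound 3 (1.76 log units; beyond the scatter). Compound 4 `O=C(NCc1ccc(C(F)(F)F)nc1OCC1CCCC1)Nc1cccc2c(=O)[nH]ccc12` differs from compound 3 by a single change: cyclopentyl in place of propyl on a saturated chain carbon bound to an oxygen on an aromatic ring. Going by the values given here, none of the measured steps touches this part of the structure; each of them exchanges the whole group on the aromatic carbon, so the data offer no direct guide to this change. The expected step is therefore one within the scatter, with only a slight lean towards a lower number: a 1.5-fold lower number from compound 3 to compound 4 (0.16 log units; within the scatter) is the estimate. Compound 4 is expected at 110 nM, with a range from 30 nM to 400 nM.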

Compound 4, half-maximal effective concentration: 15.5 nM
Estimate against measurement, compound 4: 7.1-fold (0.85 log units) above; measured number outside the range, below it.
By their numbers in this assay, from the lowest: compound 2; then compounds 1 and 4 (each within the scatter of the next); then compound 3.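

The group on the oxygen matters here, and not only the atom bound to the aromatic carbon: cyclopentyl in place of propyl gives a 10-fold lower number from compound 3 to compound 4 (1.01 log units; beyond the scatter) with the oxygen unchanged. The cyclopentylmethoxy group also brings a 1.2-fold higher number from compound 1 to compound 4 (0.07 log units; within the scatter) against piperidin-1-yl, while dipropylamino keeps its lead, with a 5.6-fold higher number from compound 2 to compound 4 (0.74 log units; beyond the scatter) in the other comparison. No measurement shown here explains these shifts. Still open, going by these compounds, is whether cyclohexyl or cyclopropyl on the same chain carbon would shift the number further, and whether a dipropylamino relative such as dibutylamino would extend that lead.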